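Methoxyphenyl in place of difluorophenyl on the hydrazone carbon

A few compounds are considered here, and "the series" means these few. Any claim that something is new, unique, unknown or untested is made for them only; others in the source may bear on it.

Compound 1, `CN(C)C/C=C/C(=O)Nc1cccc(Nc2nc(N/N=C/c3ccc(F)cc3)ncc2Cl)c1`: in an ADME assay on HT-29 cells (Homo sapiens) for inhibition, read by MTT assay, with a stated time of 72 h (on this read-out higher numbers stand for weaker inhibition and lower numbers for stronger inhibition), compound 1 gives 3300 nM.
Compound 2, `CN(C)C/C=C/C(=O)Nc1cccc(Nc2nc(N/N=C/c3ccc(F)cc3F)ncc2Cl)c1`: in this assay compound 2 gives 2920 nM.

Compound 2 carries the lowest of the two numbers, yet its nearest neighbour is compound 1 and the step of a 1.1-fold lower number from compound 1 to compound 2 (0.05 log units; within the scatter) lies within the scatter. Compound 3, `COc1ccc(/C=N/Nc2ncc(Cl)c(Nc3cccc(NC(=O)/C=C/CN(C)C)c3)n2)cc1`, differs from compound 2 by 4-methoxyphenyl in place of 2,4-difluorophenyl on a carbon with a double bond to nitrogen. Among the compounds with values here, the one measured step, a 1.1-fold lower number from compound 1 to compound 2 (0.05 log units; within the scatter), altered the 2,4-difluorophenyl that now leaves and stayed within the scatter, so no step beyond the scatter is expected in this assay. Compound 3 is expected to give 3100 nM, between 1200 nM and 8000 nM, a step of a 1.1-fold higher number from compound 2 to compound 3 (0.03 log units; within the scatter) that is expected to remain within the scatter.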

Compound 3, half-maximal inhibitory concentration: 4820 nM
Estimate against measurement, compound 3: 1.6-fold (0.19 log units) below, within the range that was stated.
By their numbers in this assay, from the lowest: compounds 2, 1 and 3 (each within the scatter of the next).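

At this carbon with a double bond to nitrogen, 4-methoxyphenyl in place of 2,4-difluorophenyl gives a 1.7-fold higher number from compound 2 to compound 3 (0.22 log units; within the scatter) in this assay, and methoxy in place of fluoro on an aromatic carbon gives a 1.5-fold higher number from compound 1 to compound 3 (0.16 log units; within the scatter). So the change at this position now extends beyond fluoro to an oxygen-linked group, and still no step leaves the scatter. Nothing available bears on what lies behind these numbers. Open, going by these compounds, is whether an amine or a carboxylic acid on this ring would also stay within the scatter. A pyridine ring in place of the phenyl is equally untested by the compounds shown here.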